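The source may report more compounds than this note shows. Statements on the series, on what has been measured and on what is new or still open speak of the compounds shown alone.

Measured in an ADME assay on Huh-7 cells (Homo sapiens) for cytotoxicity, read by MTT assay; on this read-out higher numbers stand for weaker inhibition and lower numbers for stronger inhibition:
compound 1 `Cc1ccc2nc([C@H](CC3CCN(C(=O)C(C)C)CC3)N3C(=O)CN(c4ccc(Oc5ccc(F)cc5)cc4)C3=O)n(C3CC3)c2c1`: > 100000 nM
compound 2 `CC(C)C(=O)N1CCC(C[C@@H](c2nc3ccc(F)cc3n2C)N2C(=O)CN(c3ccc(Oc4ccc(F)cc4)cc3)C2=O)CC1`: > 100000 nM

Compound 2 stands at > 100000 nM, which is a limit of the assay and not a number. Both measured compounds share one reading: the limit of > 100000 nM in this assay, at which 2 of the 2 values shown sit. Compound 3 `Cc1ccc2nc([C@H](CC3CCN(C(=O)C(C)C)CC3)N3C(=O)CN(c4ccc(Oc5ccc(F)cc5)cc4)C3=O)n(C)c2c1` has methyl in place of fluoro on an aromatic carbon, so 6-fluoro-1-methyl-1H-benzimidazol-2-yl becomes 1,6-dimethyl-1H-benzimidazol-2-yl. Within the data shown here, no measured step shows what this change does. In this assay, the expected a number no higher from compound 2 to compound 3 (the limit leaves the size open) is none beyond the scatter, and this expectation rests on compound 1 and compound 2 sharing (the limit of > 100000 nM in this assay, at which 2 of the 2 values shown sit). For compound 3 the estimated value is 100000 nM, with an expected range of 50000 nM to 200000 nM.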

Compound 3, half-maximal inhibitory concentration: > 100000 nM
Compound 3 was reported as a limit (the forecaster's own chance of this, stated with the estimate: 90%); the middle value lies on the limit itself.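

The steps from compound 1 and compound 2 to compound 3 cannot be read, because all three compounds share one reading: the limit of > 100000 nM in this assay, at which 3 of the 3 values shown sit.

The compounds shown leave open which change, if any, would bring a readable value in this assay.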